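An Ethoxy Homologue Weighed Against One Measured Pair

The source may report more compounds than this note shows. Statements on the series, on what has been measured and on what is new or still open speak of the compounds shown alone.

Three compounds have been measured so far in a functional assay on MOLT-3 cells (Homo sapiens) for antiproliferative activity; a lower number here means a stronger inhibitor, a higher number a weaker inhibitor:

Compound 1, `CCCNC(=O)c1cccc(NC(=O)C(C)Br)c1`: 8940 nM.
Compound 2, `CCCCNC(=O)c1cccc(NC(=O)C(C)Br)c1`: only a limit, > 10000 nM.
Compound 3, `COc1ccc(NC(=O)c2cc(NC(=O)C(C)Br)ccc2F)cc1`: 250 nM.

Compound 2 has in this assay no number but a limit, > 10000 nM; this is the limit of > 10000 nM in this assay, at which 1 of the 3 values shown sits. Compound 1 and compound 2 differ by methyl in place of hydrogen on a saturated chain carbon, three bonds along the chain from an amide-type nitrogen, and that change gave an at least 1.1-fold higher number from compound 1 to compound 2 (0.04 log units; that floor lies within the scatter). Compound 3 stands apart from both: how its core differs from the core of compound 1 is not broken down here.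

Compound 4, `CCOc1ccc(NC(=O)c2cc(NC(=O)C(C)Br)ccc2F)cc1`, has not yet been measured. It differs from compound 3 by methyl in place of hydrogen on a saturated chain carbon bound to an oxygen on an aromatic ring. This is the same kind of change as from compound 1 to compound 2, a methyl in place of hydrogen on a saturated chain carbon, but not the same change: in compound 2 the carbon sits three bonds along the chain from an amide-type nitrogen, while in compound 4 it is bound to an oxygen on an aromatic ring. Among the measured compounds shown here, the one measured example of this kind was a small step, so a small step is expected here as well: from compound 3 to compound 4 the expected change is a 1.3-fold higher number from compound 3 to compound 4 (0.11 log units; within the scatter), resting on an at least 1.1-fold higher number from compound 1 to compound 2 (0.04 log units; that floor lies within the scatter). Compound 4 is therefore estimated at about 320 nM, between 120 nM and 900 nM.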

Compound 4, half-maximal inhibitory concentration: > 10000 nM
Compound 4 ended at the assay's limit; the forecaster's own chance of this, stated with the estimate: 3%; middle value at least 31-fold (1.49 log units) away from the limit.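

On the core of compound 3 in this assay, replacing methoxy with ethoxy was a large change, not a small one: an at least 40-fold higher number from compound 3 to compound 4 (1.60 log units; beyond the scatter). Compound 4 gives only a limit of the assay and no exact number, and compound 2 sits at that same limit: the limit of > 10000 nM in this assay, at which 2 of the 4 values shown sit. The result shows that a small-looking step on the core of compound 1 gave no safe guide to the size of this kind of change on the core of compound 3, but it does not show that the two steps truly differ, and the methyl also sits in a different place in each pair: the same change on two cores in this assay, an at least 1.1-fold higher number (0.04 log units; that floor lies within the scatter) from compound 1 to compound 2 and an at least 40-fold higher number (1.60 log units; beyond the scatter) from compound 3 to compound 4; the limit leaves it open whether they differ.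

Still open, going by these compounds, is how large each step really is, and whether the sharp rise on the core of compound 3 already appears with any group larger than methoxy. It is also unclear how this core would respond to a longer chain such as propoxy, or to an amine in the same place.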